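Swapping the ends of the amide chain in compound 3

The source may report more compounds than this note shows. Statements on the series, on what has been measured and on what is new or still open speak of the compounds shown alone.

In an ADME assay on CEM-SS cells (Homo sapiens) for cytotoxicity, read by XTT assay, with a stated time of 6 days (a lower number here means that less compound is tolerated, a higher number that more compound is tolerated), compound 2, `CCCC(=O)OCSc1ccccc1C(=O)NCCCCCCC(N)=O`, gives 10.4 uM. Within the data shown here, that is the only number among the values shown. Compound 1, `NC(=O)CCNC(=O)c1cccc(S)c1`, reaches a limit in this assay and gives > 100 uM. The limit itself is described thus: the limit of > 100 uM in this assay, at which 1 of the 2 values shown sits. Compound 3, `CCCCCNC(=O)CNC(=O)c1ccccc1SCOC(=O)CCC`, is not yet measured in this assay. It differs from compound 2 by pentylcarbamoyl in place of 5-carbamoylpentyl on a saturated chain carbon bound to an amide-type nitrogen. No step between measured compounds is shown, so only a step within the usual scatter, in no set direction, is expected in this assay. Compound 3 is expected to give 11 uM, somewhere between 4 uM and 30 uM. The expected step is a 1.1-fold higher number from compound 2 to compound 3 (0.02 log units; within the scatter).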

Compound 3, half-maximal toxic concentration: 24.8 uM
Compound 3: middle estimate off by 2.3-fold (0.35 log units), on the low side; the range from low to high includes it.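

In this assay, pentylcarbamoyl in place of 5-carbamoylpentyl on a saturated chain carbon bound to an amide-type nitrogen gives a 2.4-fold higher number from compound 2 to compound 3 (0.38 log units; beyond the scatter). Among these compounds, this is the first step read at this place, and it shows that the same atoms, joined differently, can move the number beyond the scatter with no atom gained or lost. Nothing shown gives a cause for this step. Still open, from the compounds shown here alone, is how an amine or a carboxylic acid in place of pentylcarbamoyl on that carbon would read. Going by these compounds, a longer chain there remains equally open.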